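The source may hold more compounds than are shown below. What is called first, only, known or untested is meant among the compounds shown, and "the series" means these compounds.

For the measured compounds named here, in a functional assay on HeLa cells (Homo sapiens) for antiproliferative activity, read by MTT assay, with a stated time of 48 h (a higher number here means a weaker inhibitor, a lower number a stronger inhibitor), compound 2 `COc1cc(C(=O)/C=C/c2c[nH]c3ccccc23)cc([N+](=O)[O-])c1OC` gives 1350 nM, the second highest of the three numbers measured so far. In this assay compound 1 `COc1ccc2c(/C=C/C(=O)c3cc(OC)c(OC)c([N+](=O)[O-])c3)c[nH]c2c1` gives 850 nM and compound 3 `COc1cc(C(=O)/C=C/c2cn(C)c3ccccc23)cc([N+](=O)[O-])c1OC` gives 1960 nM; the steps of a 1.6-fold higher number from compound 1 to compound 2 (0.20 log units; within the scatter) and a 1.5-fold higher number from compound 2 to compound 3 (0.16 log units; within the scatter) both lie within the scatter, so the three measured compounds cannot be told apart. Compound 4 `COc1cc(C(=O)/C=C/c2c[nH]c3ccccc23)cc(N)c1OC` differs from compound 2 in one place: amino in place of nitro on an aromatic carbon. Going by the values given here, neither measured step touches the nitro group, so no measured step bears on this change, and the expectation rests on the narrow spread of the three numbers alone. Compound 4 is therefore expected, with wide uncertainty, to give about 2000 nM, between 600 nM and 7000 nM. This estimate amounts to an expected 1.5-fold higher number from compound 2 to compound 4 (0.17 log units; within the scatter).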

Compound 4, half-maximal inhibitory concentration: 529 nM
Compound 4: the middle estimate sits 3.8-fold (0.58 log units) above what was measured; the whole stated range lies above it.
By their numbers in this assay, from the lowest: compounds 4, 1, 2 and 3 (each within the scatter of the next, the first and the last beyond it).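

In this assay, amino in place of nitro gives a 2.6-fold lower number from compound 2 to compound 4 (0.41 log units; beyond the scatter), a modest step, but unlike the two earlier steps it lies beyond the scatter. The earlier compounds shown here all carry the nitro group, so only this result shows that the number responds to a change at this position, on an aromatic carbon ortho to a methoxy group. Nothing available explains why the amino compound gives the lower number. On these data alone, whether a hydroxyl or an acetamide here would give a number like that of compound 4 stays open. Also open, as far as these compounds go, is whether the same change would give a similar step starting from compound 1 or compound 3.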